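The source may hold more compounds than are shown below. What is called first, only, known or untested is meant among the compounds shown, and "the series" means these compounds.

In a functional assay on the whole organism for positive allosteric modulation, with Mus musculus as the target (a lower number here means that less compound is needed, a higher number that more compound is needed for the effect), compound 1 (`CCC(=O)N(c1ccc(Cl)cc1)C1CCCCC1N(C)C`) stands at 35 mg/kg and compound 3 (`CCC(=O)N(c1ccc(F)c(Cl)c1)C1CCCC1N(C)C`) at 0.2 mg/kg with compound 2 (`CCC(=O)N(c1ccc(F)cc1)C1CCCC1N(C)C`) at 5 mg/kg as the second highest of the three numbers. Compound 4 (`CCC(=O)N(c1ccc([N+](=O)[O-])cc1)C1CCCC1N(C)C`) carries nitro in place of fluoro on an aromatic carbon and remains unmeasured. For the measured compounds named here, the only measured step in one place is a 25-fold lower number from compound 2 to compound 3 (1.40 log units; beyond the scatter) for chloro in place of hydrogen on an aromatic carbon. Going by the values given here, that step is large but leaves the fluoro untouched, and no measured step replaces that group. On these data alone, no step beyond the scatter is therefore expected in this assay and the direction stays open. The expected step is a 1.3-fold lower number from compound 2 to compound 4 (0.10 log units; within the scatter) with wide uncertainty. For compound 4 the estimated value is 4 mg/kg with an expected range from 0.8 mg/kg to 25 mg/kg as the working estimate.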

Compound 4, dose for half-maximal effect: 20 mg/kg
Beside the measured number, compound 4's estimate is 5.0-fold (0.70 log units) below it, and the stated range covers the measured number.
By their numbers in this assay, from the lowest: compound 3; then compound 2; then compounds 4 and 1 (each within the scatter of the next).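

For the compounds shown here, the position para to a large group on the aromatic ring proves sensitive to its substituent: in this assay nitro in place of fluoro gives a 4.0-fold higher number from compound 2 to compound 4 (0.60 log units; beyond the scatter) and is the first measured change of the fluoro itself. A single pair sets a direction for these two groups only and establishes no trend. Nothing available bears on the reason for this step.

Still open, on these data alone, is how an amine or a methoxy group at this position would compare with fluoro and nitro. Also open, as far as these compounds go, is whether the nitro step would hold alongside the chloro of compound 3.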